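The compounds below may be only part of what the source reports. "The series", "measured", "known", "first", "only" and "open" are said of these compounds alone.

Measured so far: compound 1 `Cc1cccc(S(=O)(=O)Nc2cccc(/C=C/C(=O)c3nc4ccccc4[nH]3)c2)c1` with 791 nM in a functional assay on 143B cells (Homo sapiens) for antiproliferative activity, read by MTT assay, with a stated time of 48 h (on this read-out higher numbers stand for weaker inhibition and lower numbers for stronger inhibition), and compound 2 `O=C(/C=C/c1cccc(NS(=O)(=O)c2cc(Cl)cc(Cl)c2)c1)c1nc2ccccc2[nH]1` with 5950 nM.

Compound 2 gives the highest number of the two, the nearest being compound 1, reached by a 7.5-fold higher number from compound 1 to compound 2 (0.88 log units; beyond the scatter). Compound 3 `Cc1cc(C)cc(S(=O)(=O)Nc2cccc(/C=C/C(=O)c3nc4ccccc4[nH]3)c2)c1` is not yet measured; it differs from compound 2 by 3,5-dimethylphenyl in place of 3,5-dichlorophenyl on a sulfonyl sulfur. Within the data shown here, only one measured step bears on this: the step from compound 1 to compound 2 put a 3,5-dichlorophenyl in place of a 3-methylphenyl on the same sulfonyl sulfur and raised the number markedly. Among the measured compounds shown here, the change to compound 3 removes both chlorines again and brings a methyl-bearing ring back, so a lower number than compound 2 is expected in this assay, probably of a size comparable to that step, though with only one step to rest on the range is wide. Compound 3 is therefore estimated at 1100 nM, with a range from 400 nM to 3500 nM, which would mean an expected step of a 5.4-fold lower number from compound 2 to compound 3 (0.73 log units; beyond the scatter).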

Compound 3, half-maximal inhibitory concentration: 3330 nM
The estimate for compound 3 lay 3.0-fold (0.48 log units) below the measured number; low and high end bracket the measured number.
By their numbers in this assay, from the lowest: compound 1; then compounds 3 and 2 (each within the scatter of the next).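

In this assay, 3,5-dimethylphenyl in place of 3,5-dichlorophenyl on the sulfonyl sulfur gives a 1.8-fold lower number from compound 2 to compound 3 (0.25 log units; within the scatter), so these two rings cannot be told apart here and the chlorine atoms are not needed for the higher number seen with compound 2. Adding one methyl to an aromatic carbon gives a 4.2-fold higher number from compound 1 to compound 3 (0.62 log units; beyond the scatter), which shows that among these compounds the 3-methylphenyl ring alone keeps the low number, while both disubstituted rings lose it, whether they carry methyl or chlorine. No measurement shown explains why this second substituent matters.

What the compounds leave open is how an unsubstituted phenyl ring would compare on this sulfonyl sulfur. Also open, as far as these compounds go, is whether a methoxy group or an amine on that ring would behave as the methyl does.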